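The source may hold more compounds than are shown below. What is called first, only, known or untested is meant among the compounds shown, and "the series" means these compounds.

Compound 2, `O=C1COc2ccc(NC(=O)C3CCN(c4ccccc4Cl)CC3)cc2N1`, stands with the highest number of the three compounds measured in an assay on HEK293 cells for displacement of a labelled ligand from transient receptor potential cation channel subfamily V member 1 (Homo sapiens) (on this read-out higher numbers stand for weaker inhibition and lower numbers for stronger inhibition), where compound 2 gives 93 nM. Its neighbours are close: compound 1, `O=C1COc2ccc(NC(=O)C3CCN(c4ccccc4Br)CC3)cc2N1`, gives 71 nM, and compound 3, `O=C1COc2ccc(NC(=O)C3CCN(c4cc(F)c(F)c(F)c4)CC3)cc2N1`, gives 49 nM. None of the three is separated from another by more than the usual scatter, as the steps show: a 1.3-fold higher number from compound 1 to compound 2 (0.12 log units; within the scatter), a 1.4-fold lower number from compound 1 to compound 3 (0.16 log units; within the scatter) and a 1.9-fold lower number from compound 2 to compound 3 (0.28 log units; within the scatter).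

The next compound, compound 4, `Cc1cccc(N2CCC(C(=O)Nc3ccc4c(c3)NC(=O)CO4)CC2)c1`, differs from compound 2 in one place: 3-methylphenyl in place of 2-chlorophenyl on an amine nitrogen in a ring. Among the measured compounds shown here, two measured steps bear on this. The step from compound 1 to compound 2 exchanges one halogen for another on the same aromatic carbon, and the step from compound 2 to compound 3 exchanges the whole aryl group on the ring amine nitrogen for a differently substituted one; both stayed within the scatter, the second being the larger of the two. For the measured compounds named here, no measured compound carries a methyl on this phenyl ring, so the new group itself is untested. Since every aryl variation seen so far left this assay unchanged beyond the scatter, compound 4 is expected to sit near compound 2, with the expected step being a 1.0-fold lower number from compound 2 to compound 4 (0.01 log units; within the scatter). The estimate for compound 4 is therefore 90 nM, with a likely range from 35 nM to 250 nM.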

Compound 4, inhibition constant: 225 nM
Compound 4: middle estimate off by 2.5-fold (0.40 log units), on the low side; the range from low to high includes it.
By their numbers in this assay, from the lowest: compounds 3, 1 and 2 (each within the scatter of the next); then compound 4.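

In this assay the aryl group on the amine nitrogen in a ring turns out not to be free to vary, although the three halogen-bearing aryl groups of compound 1, compound 2 and compound 3 had given no sign of this. Among the compounds shown here, putting 3-methylphenyl in place of 2-chlorophenyl gives the first change here beyond the scatter (a 2.4-fold higher number from compound 2 to compound 4 (0.38 log units; beyond the scatter)), and the same group also stands apart from 2-bromophenyl (a 3.2-fold higher number from compound 1 to compound 4 (0.50 log units; beyond the scatter)) and from 3,4,5-trifluorophenyl (a 4.6-fold higher number from compound 3 to compound 4 (0.66 log units; beyond the scatter)), so the higher number holds against all three aryl groups, though each of these steps remains modest. Nothing at hand explains why the number rises with this group.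

On these data alone, what stays open is whether the rise goes with the methyl group itself or with its place on the phenyl ring, which a matched pair of 2-methylphenyl and 3-chlorophenyl would help to separate. As far as these compounds go, it is also open how far the trend extends to other groups on this phenyl ring, such as methoxy, trifluoromethyl or a nitrile, or to a pyridyl ring in place of the phenyl.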